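Bromo to Chloro: a Small Change Made Twice

A few compounds are considered here, and "the series" means these few. Any claim that something is new, unique, unknown or untested is made for them only; others in the source may bear on it.

Compound 1 `COc1ccc(C2=NN(C3=NC(=O)/C(=C4\C(=O)Nc5ccc(Br)cc54)S3)C(c3ccc(OC)cc3)C2)cc1` and compound 2 `COc1ccc(C2=NN(C3=NC(=O)/C(=C4\C(=O)Nc5ccc(Cl)cc54)S3)C(c3ccc(OC)cc3)C2)cc1` share one core, while compound 3 `CN(C)c1ccc(C2CC(c3ccccc3)=NN2C2=NC(=O)/C(=C3\C(=O)Nc4ccc(Br)cc43)S2)cc1` and compound 4 `CN(C)c1ccc(C2CC(c3ccccc3)=NN2C2=NC(=O)/C(=C3\C(=O)Nc4ccc(Cl)cc43)S2)cc1` share another; the difference between the two cores is not broken down here. Within each pair the structural change is the same. From compound 1 to compound 2 it is chloro in place of bromo on an aromatic carbon, and from compound 3 to compound 4 it is chloro in place of bromo on an aromatic carbon. The surroundings of the exchanged group are described in identical words for both pairs, so the second swap is the same change as the first, simply made on a different core.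

In a functional assay on cells (Cancer cell lines, Homo sapiens) for cytotoxicity, read by sulforhodamine B assay, with a stated time of 48 h (on this read-out higher numbers stand for weaker inhibition of growth and lower numbers for stronger inhibition of growth), compound 1 gives 200 nM and compound 2 gives 200 nM. The step of no change at the digits printed from compound 1 to compound 2 (within the scatter) shows that the swap left the growth-inhibiting potency essentially where it was. Compound 3 gives 210 nM in this assay, a number that sits within the scatter of both compound 1 and compound 2.

Compound 4 has not yet been measured. Because the earlier step of no change at the digits printed from compound 1 to compound 2 (within the scatter) was flat, the same swap is expected to be flat again, and the expected step is no change at the digits printed from compound 3 to compound 4 (within the scatter), beside the measured one. This expectation rests on a single prior observation, so it is held loosely. Compound 4 is therefore estimated at 210 nM, with a likely range from 120 nM to 380 nM.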

Compound 4, concentration for 50% growth inhibition: 190 nM
Compound 4: middle estimate off by 1.1-fold (0.04 log units), on the high side; low and high end bracket the measured number.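

In this assay, putting chloro in place of bromo on an aromatic carbon of the second core gives a 1.1-fold lower number from compound 3 to compound 4 (0.04 log units; within the scatter), so the swap is flat on this core as well. Set side by side, the two steps cannot be told apart, and in this assay the exchange carries from one core to the other without a detectable difference: the same change on two cores in this assay, no change at the digits printed (within the scatter) from compound 1 to compound 2 and a 1.1-fold lower number (0.04 log units; within the scatter) from compound 3 to compound 4, 1.1-fold (0.04 log units) apart, within the scatter of two such steps. This shows only that these two halogens can stand in for each other on these two cores in this single assay; a pair of flat steps does not show that a change with a real effect on growth inhibition would carry across in the same way, and it gives no reason why the swap does so little.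

The compounds shown leave open what a quite different group on the same aromatic carbon, such as an amine, a carboxylic acid or a longer alkyl chain, would do to growth inhibition, and whether any such effect would match on both cores. They also leave open what each structural difference between the two cores contributes, since those cores differ in more than one place and no single change separates them.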